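Swapping a chlorophenyl arm for a methoxyphenyl on the shared core

The source may hold more compounds than are shown below. What is called first, only, known or untested is meant among the compounds shown, and "the series" means these compounds.

Compound 1 `COc1cc(-n2cnc3ccc(-c4cccc(Cl)c4)cc32)cc(OC)c1OC`: 1490 nM
Compound 2 `COc1cc(-c2ccc3ncn(-c4cc(OC)c(OC)c(OC)c4)c3c2)cc(OC)c1OC`: > 10000 nM

Two compounds have been run in a functional assay on SGC-7901 cells (Homo sapiens) for antiproliferative activity, read by MTT assay, with a stated time of 72 h; a higher number here means a weaker inhibitor, a lower number a stronger inhibitor. Within the data shown here, compound 1 gives 1490 nM, the only numeric value available, so it stands alone as the reference point. Compound 2 reaches only a limit of the assay, > 10000 nM, and is not a number; the limit situation is summarised by the limit of > 10000 nM in this assay, at which 1 of the 2 values shown sits. Among the measured compounds shown here, no pair of compounds differing in a single place has been measured, so no step size is known from the data.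

Compound 3 `COc1ccc(-c2ccc3ncn(-c4cc(OC)c(OC)c(OC)c4)c3c2)cc1` has not been measured. It differs from compound 1 by 4-methoxyphenyl in place of 3-chlorophenyl on an aromatic carbon, a change on the aromatic carbon of the shared core that is meta to a fused ring and para to a fused ring. With compound 2 sitting at the limit after a change on the same core, a weakening beyond the usual scatter is expected, though a smaller one than that seen for compound 2. Compound 3 is therefore estimated at 3500 nM, between 900 nM and 12000 nM, a step of a 2.3-fold higher number from compound 1 to compound 3 (0.37 log units; beyond the scatter) expected in this assay.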

Compound 3, half-maximal inhibitory concentration: 82 nM
Estimate against measurement, compound 3: 43-fold (1.63 log units) above, and the stated range ends above it.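

Among these compounds, replacing 3-chlorophenyl with 4-methoxyphenyl gives an 18-fold lower number from compound 1 to compound 3 (1.26 log units; beyond the scatter) in this assay and is the only single-place step on the shared core that can be read as a number. It shows that this aromatic carbon, meta to a fused ring and para to a fused ring, is highly sensitive to the aryl arm it carries, and that a change here can strengthen the compound rather than weaken it. Compound 2, whose arm at the same carbon also carries methoxy groups, shows no such gain and stands at a limit of the assay: the limit of > 10000 nM in this assay, at which 1 of the 3 values shown sits.

The step from compound 1 to compound 3 changes both the substituent on the arm and its place, so the compounds shown cannot separate the two; a 3-methoxyphenyl or a 4-chlorophenyl arm at this carbon would be needed to tell them apart. Going by these compounds, it also remains open how this carbon would respond to a 4-aminophenyl arm, a 4-ethoxyphenyl arm or a 4-carboxyphenyl arm, or to having no aryl arm at all.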